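Cytotoxicity on mouse cells: swapping a pyrazole for a benzamide

The source may report more compounds than this note shows. Statements on the series, on what has been measured and on what is new or still open speak of the compounds shown alone.

Compound 2 `FC(F)(F)Oc1ccc(Nc2cc(-c3cn[nH]c3)ncn2)cc1` sits at a limit of an ADME assay on BaF3 cells (Mus musculus) for cytotoxicity; on this read-out higher numbers stand for an effect only at larger amounts of compound and lower numbers for an effect already at smaller amounts: it gives > 10000 nM, a limit and not a number. Compound 1 `NC(=O)c1ccc(-c2cc(Nc3ccc(OC(F)(F)F)cc3)ncn2)cc1` likewise gives > 10000 nM, again a limit. The step that the two limits leave unreadable from compound 1 to compound 2 therefore cannot be read, since the limit of > 10000 nM in this assay, at which 2 of the 2 values shown sit, covers both. Compound 3 `NC(=O)c1ccccc1-c1cc(Nc2ccc(OC(F)(F)F)cc2)ncn1` differs from compound 2 by 2-carbamoylphenyl in place of 1H-pyrazol-4-yl on an aromatic carbon. Within the data shown here, no measured step gives a readable size for a change of this kind, so no shift beyond the scatter is expected, and the step that the limit leaves unreadable from compound 2 to compound 3 is an estimate of no movement. Compound 3 is expected to give 15000 nM, with a range from 5000 nM to 50000 nM.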

Compound 3, half-maximal effective concentration: > 10000 nM
Compound 3: no number, only a limit (the forecaster's own chance of this, stated with the estimate: 85%); the middle value is on the limit's open side.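

In this assay, among these compounds, no step among compound 1, compound 2 and compound 3 can be read, since all three give a limit and not a number: the limit of > 10000 nM in this assay, at which 3 of the 3 values shown sit. Going by these compounds, how far apart these compounds truly lie stays open, as does whether swapping these groups changes the read-out at all.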